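The source may report more compounds than this note shows. Statements on the series, on what has been measured and on what is new or still open speak of the compounds shown alone.

Compound 1 `Cc1cc(NC(=O)c2cnc(Cl)nc2C(F)(F)F)on1` gives 4000 nM in an assay on Jurkat cells for inhibition of nuclear factor NF-kappa-B p105 subunit (Homo sapiens); a lower number here means a stronger inhibitor, a higher number a weaker inhibitor.
Compound 2 `O=C(Nc1cc(C(F)(F)F)cc(C(F)(F)F)c1)c1cnc(Cl)nc1C(F)(F)F` gives 50 nM in this assay.

Compound 2 holds the lower of the two numbers in this assay, and its gap to compound 1 is beyond the usual scatter. Compound 3 `CCCCCCOC(=O)c1cc(NC(=O)c2cnc(Cl)nc2C(F)(F)F)cc(C(F)(F)F)c1` keeps the shared core of compound 2 and changes one group: hexyloxycarbonyl in place of trifluoromethyl on an aromatic carbon. Within the data shown here, no pair of measured compounds shows the effect of such an exchange, so its direction is open. A moderate rise in the number, beyond the scatter, is expected for the step of a 3.0-fold higher number from compound 2 to compound 3 (0.48 log units; beyond the scatter). Compound 3 is estimated at 150 nM, within 30 nM to 1000 nM.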

Compound 3, half-maximal inhibitory concentration: 620 nM
The estimate for compound 3 lay 4.1-fold (0.62 log units) below the measured number; the measured number falls inside the stated range.
By their numbers in this assay, from the lowest: compound 2; then compound 3; then compound 1.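

The exchange now has a measured direction and size at this position on the aromatic ring. In this assay, hexyloxycarbonyl in place of trifluoromethyl gives a large rise, a 12-fold higher number from compound 2 to compound 3 (1.09 log units; beyond the scatter), so this position does not accept the longer group without a loss. The other trifluoromethyl group and the rest of compound 2 stay unchanged, which ties the step to this one exchange, but no measurement at hand says what lies behind it.

Still open, going by these compounds, is whether the rise follows the hexyl chain or the carbonyl and its oxygens. A methyl ester or a carboxylic acid at this position would help separate the two.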